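The source may report more compounds than this note shows. Statements on the series, on what has been measured and on what is new or still open speak of the compounds shown alone.

Compound 3, with the structure `CN1CCC(n2cc(S(=O)(=O)c3ccccc3)c3cccnc32)C1`, gives 2.5 nM in an assay on HeLa cells for displacement of a labelled ligand from 5-hydroxytryptamine receptor 6 (Homo sapiens); on this read-out higher numbers stand for weaker inhibition and lower numbers for stronger inhibition; this is the lowest of the three numbers, though compound 1, with the structure `O=S(=O)(c1cccc(F)c1)c1cn(C2CCNC2)c2ncccc12` and a value of 2.7 nM, sits within the scatter of it, while compound 2, with the structure `O=S(=O)(c1ccc(F)cc1)c1cn(C2CCNC2)c2ncccc12` and a value of 8.5 nM, lies beyond it. Compound 4, with the structure `CN1CCC(n2cc(S(=O)(=O)c3cccc(F)c3)c3cccnc32)C1`, differs from compound 3 by fluoro in place of hydrogen on an aromatic carbon. Going by the values given here, no measured pair shows this exact exchange; the nearest step, a 3.1-fold higher number from compound 1 to compound 2 (0.50 log units; beyond the scatter), compares two fluorine positions rather than fluorine against hydrogen. Compound 1 already carries the 3-fluorophenyl group and gives a number close to that of compound 3, so for compound 4 only a small change, no change at the digits printed from compound 3 to compound 4 (within the scatter), is expected. The estimate for compound 4 is 2.5 nM, with a range from 1.2 nM to 5.5 nM.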

Compound 4, inhibition constant: 1.4 nM
Estimate against measurement, compound 4: 1.8-fold (0.25 log units) above; the range from low to high includes it.
By their numbers in this assay, from the lowest: compounds 4, 3 and 1 (each within the scatter of the next); then compound 2.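

In this assay, fluoro in place of hydrogen on this aromatic carbon gives a 1.8-fold lower number from compound 3 to compound 4 (0.25 log units; within the scatter), so the 3-fluorophenyl group and plain phenyl cannot be told apart here. Methyl in place of hydrogen on the ring amine nitrogen, with 3-fluorophenyl kept, gives a 1.9-fold lower number from compound 1 to compound 4 (0.29 log units; within the scatter), so this change cannot be told from no change either. Nothing measured here offers an explanation for either result. Going by these compounds, whether the 4-fluorophenyl group of compound 2 would also give a higher number with methyl on the ring nitrogen stays open. So does the effect of chloro or methoxy at this place.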